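Swapping the Chain Amine in a Cytotoxic Series

This account rests on a few compounds, and the source may have more. Where it says the series, first, only, none or still open, it means among the compounds named here.

Within the data shown here, compound 1 `COc1cc2c(Oc3ccc(NC(=O)c4cn(-c5ccccc5F)nn4)cc3F)ccnc2cc1OCCCN1CCCCC1` is one of two compounds measured in a functional assay on MKN-45 cells (Homo sapiens) for cytotoxicity, read by MTT assay, with a stated time of 72 h; a higher number here means a weaker inhibitor, a lower number a stronger inhibitor. In this assay compound 1 gives 1290 nM, the lowest of the two numbers. Among the measured compounds shown here, its only measured neighbour is compound 2 `COc1cc2c(Oc3ccc(NC(=O)c4cn(-c5c(C)cccc5C)nn4)cc3F)ccnc2cc1OCCCN1CCCCC1`, which gives 2140 nM in this assay; the step of a 1.7-fold higher number from compound 1 to compound 2 (0.22 log units; within the scatter) concerns 2,6-dimethylphenyl in place of 2-fluorophenyl on an aromatic nitrogen and stays within the scatter. Compound 3 `COc1cc2c(Oc3ccc(NC(=O)c4cn(-c5ccccc5F)nn4)cc3F)ccnc2cc1OCCCN1CCN(C)CC1` has not yet been measured. It differs from compound 1 in a single place: 4-methylpiperazin-1-yl in place of piperidin-1-yl on a saturated chain carbon, three bonds along the chain from an oxygen on an aromatic ring. For the measured compounds named here, no measured step touches this part of the molecule; the one step recorded changes a different region, the aryl group on an aromatic nitrogen, and lies within the scatter, so it offers no direction for the present change. Without any measured step bearing on the change, the expectation for compound 3 is no shift beyond the scatter, that is an estimated step of a 1.0-fold higher number from compound 1 to compound 3 (0.00 log units; within the scatter). Compound 3 is therefore expected to give about 1300 nM in this assay, within a range from 500 nM to 3500 nM.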

Compound 3, half-maximal inhibitory concentration: 140 nM
Compound 3: the middle estimate sits 9.3-fold (0.97 log units) above what was measured; measured number outside the range, below it.
By their numbers in this assay, from the lowest: compound 3; then compounds 1 and 2 (each within the scatter of the next).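

In this assay the amine at the end of the propyl chain proves to be a place where the number can move: 4-methylpiperazin-1-yl in place of piperidin-1-yl brings a 9.2-fold lower number from compound 1 to compound 3 (0.96 log units; beyond the scatter) and so clears the scatter, which the step at the aryl group on an aromatic nitrogen did not. Among the compounds shown, this position is therefore the only one with a step beyond the scatter, and the change that achieves it adds a second ring nitrogen, which carries a methyl group. Nothing measured alongside these numbers accounts for the shift.

Morpholine or an unsubstituted piperazine at the chain end might tell whether the methyl group or the second ring nitrogen goes with the lower number, and 2-(4-methylpiperazin-1-yl)ethyl would test the same amine on a shorter chain. It also remains open whether the 4-methylpiperazin-1-yl group would bring a similar step on the 2,6-dimethylphenyl compound 2, since the change is shown only with the 2-fluorophenyl group in place.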